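Changing the Ring on the Amide-Type Nitrogen

The source may report more compounds than this note shows. Statements on the series, on what has been measured and on what is new or still open speak of the compounds shown alone.

In a functional assay on KB cells (Homo sapiens) for antiproliferative activity, read by sulforhodamine B assay, with a stated time of 48 h (a higher number here means a weaker inhibitor of growth, a lower number a stronger inhibitor of growth), compound 1 `COc1ccc(S(=O)(=O)Nc2ccccc2CCc2ccc(C(=O)NO)cc2)cc1` gives > 10000 nM, which is a limit of the assay and not a number. Going by the values given here, compound 2 `COc1ccc(S(=O)(=O)Nc2ccccc2CCc2ccc(C(=O)Nc3ccccc3O)cc2)cc1` gives 472 nM, the only true number so far. Among the compounds with values here, the one measured step, an at least 21-fold lower number from compound 1 to compound 2 (1.32 log units; beyond the scatter), is large and comes from 2-hydroxyphenyl in place of hydroxy on the amide-type nitrogen. Compound 3 `COc1ccc(S(=O)(=O)Nc2ccccc2CCc2ccc(C(=O)Nc3cc(F)ccc3N)cc2)cc1` changes that same place again: 2-amino-5-fluorophenyl in place of 2-hydroxyphenyl on an amide-type nitrogen. Here 2-amino-5-fluorophenyl takes the place of 2-hydroxyphenyl, and one six-membered aromatic ring of carbon only stands on both sides of the swap. The large step brought that ring in, whereas this swap keeps it, so the expectation starts from compound 2 at 472 nM. No change beyond the scatter is expected in this assay, and the direction is open. The estimated change is a 1.2-fold lower number from compound 2 to compound 3 (0.07 log units; within the scatter). For compound 3 the expected value is 400 nM, within an estimated range of 100 nM to 2000 nM.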

Compound 3, concentration for 50% growth inhibition: 66 nM
Estimate against measurement, compound 3: 6.1-fold (0.78 log units) above, outside the stated range (below it).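

Compound 2 showed that a ring on the amide-type nitrogen could bring a large gain, but not that the groups on that ring matter as well. With the same six-membered aromatic ring of carbon on both sides of the swap, this assay still shows a 7.2-fold lower number from compound 2 to compound 3 (0.85 log units; beyond the scatter), so the number at this position depends on what the ring carries. Measured from the hydroxy of compound 1, the change reaches an at least 150-fold lower number from compound 1 to compound 3 (2.18 log units; beyond the scatter), and this size is only a bound, as compound 1 stands at a limit of the assay and not at a number: the limit of > 10000 nM in this assay, at which 1 of the 3 values shown sits.

The swap replaces the hydroxy with an amine and adds a fluorine at once, so the compounds shown do not tell which of the two carries the step. A ring with the amine alone, or with chlorine in the fluorine's place, would separate them.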